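Adding One Carbon: From Propyl to Butyl

A few compounds are considered here, and "the series" means these few. Any claim that something is new, unique, unknown or untested is made for them only; others in the source may bear on it.

In a functional assay on A549 cells (Homo sapiens) for inhibition, read by MTT assay, with a stated time of 72 h (on this read-out lower numbers stand for stronger inhibition and higher numbers for weaker inhibition), compound 1 (`O=C(Nc1ccccc1)C1CCN(C/C=C/c2ccccc2)CC1`) gives 69700 nM while compound 2 (`CCc1ccc(NC(=O)C2CCN(C/C=C/c3ccccc3)CC2)cc1`) gives 19600 nM and compound 3 (`CCCc1ccc(NC(=O)C2CCN(C/C=C/c3ccccc3)CC2)cc1`) gives 9470 nM as the lowest of these three numbers. Compound 4 (`CCCCc1ccc(NC(=O)C2CCN(C/C=C/c3ccccc3)CC2)cc1`) has not been measured yet. It differs from compound 3 by methyl in place of hydrogen on a saturated chain carbon, three bonds along the chain from an aromatic carbon and so turns propyl into butyl. The closest measured change is ethyl to propyl with a 2.1-fold lower number from compound 2 to compound 3 (0.32 log units; beyond the scatter) as its modest size, and both a 3.6-fold lower number from compound 1 to compound 2 (0.55 log units; beyond the scatter) and a 7.4-fold lower number from compound 1 to compound 3 (0.87 log units; beyond the scatter) run the same way. A further small step toward a lower number is therefore expected in this assay with a 1.7-fold lower number from compound 3 to compound 4 (0.24 log units; within the scatter) as the estimate, near the edge of the usual scatter. For compound 4 the estimated value is 5500 nM with an expected range from 2500 nM to 11000 nM for now.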

Compound 4, half-maximal inhibitory concentration: 5910 nM
Compound 4: middle estimate off by 1.1-fold (0.03 log units), on the low side, and the stated range covers the measured number.
By their numbers in this assay, from the lowest: compounds 4 and 3 (each within the scatter of the next); then compound 2; then compound 1.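

In this assay the butyl chain brings a 1.6-fold lower number from compound 3 to compound 4 (0.20 log units; within the scatter) and so, unlike the ethyl to propyl change, this added carbon cannot be told apart from no change. For the compounds shown here, only over a larger change in the chain do the numbers separate clearly, with a 3.3-fold lower number from compound 2 to compound 4 (0.52 log units; beyond the scatter) and a 12-fold lower number from compound 1 to compound 4 (1.07 log units; beyond the scatter) as the first large step. No supporting measurement bears on why the numbers run this way.

From the compounds shown here alone, whether a pentyl or longer chain would move the number further remains open. So does how a branched tert-butyl group or a hydroxyl at the chain end would compare.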